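Bromo in Place of Chloro on a Second Core

This account rests on a few compounds, and the source may have more. Where it says the series, first, only, none or still open, it means among the compounds named here.

Measured so far:
Compound 1 `COc1ccc(C2=NN(C(=O)c3ccc(C)nc3)C(c3ccc(Cl)cc3)C2)cc1` gives 890 nM in a functional assay on WM 266-4 cells (Homo sapiens) for antiproliferative activity, read by MTT assay, with a stated time of 24 h; on this read-out lower numbers stand for stronger inhibition of growth and higher numbers for weaker inhibition of growth.
Compound 2 `COc1ccc(C2=NN(C(=O)c3ccc(C)nc3)C(c3ccc(Br)cc3)C2)cc1` gives 4280 nM in this assay.
Compound 3 `O=C(c1cncc(Br)c1)N1N=C(c2ccc(Cl)cc2)CC1c1ccc(Cl)cc1` gives 6090 nM in this assay.

Compound 1 and compound 2 share a core and differ in one place: bromo in place of chloro on an aromatic carbon. This change produced a 4.8-fold higher number from compound 1 to compound 2 (0.68 log units; beyond the scatter). Compound 3 carries a different core; how it differs from compound 1 is not broken down here. Against compound 2, compound 3 stands within the scatter, so no order between them can be read.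

Compound 4 `O=C(c1cncc(Br)c1)N1N=C(c2ccc(Cl)cc2)CC1c1ccc(Br)cc1` is not yet measured. It relates to compound 3 as compound 2 relates to compound 1: bromo in place of chloro on an aromatic carbon. The place is the same in both pairs, so this is the same change, now made on the core of compound 3.

Because compound 1 to compound 2 gave a 4.8-fold higher number from compound 1 to compound 2 (0.68 log units; beyond the scatter), a higher number is expected for compound 4, though the change sits on a core whose own behaviour is known only from compound 3. The expected step is a 2.6-fold higher number from compound 3 to compound 4 (0.42 log units; beyond the scatter). For compound 4 the estimate in this assay is 16000 nM, between 6000 nM and 45000 nM.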

Compound 4, concentration for 50% growth inhibition: 8010 nM
The estimate for compound 4 lay 2.0-fold (0.30 log units) above the measured number; the range from low to high includes it.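

On the core of compound 3, bromo in place of chloro gave a 1.3-fold higher number from compound 3 to compound 4 (0.12 log units; within the scatter) in this assay, so the change leaves no readable difference on this core. Set beside the earlier step, the change did not carry over at its former size from one core to the other: the same change on two cores in this assay, a 4.8-fold higher number (0.68 log units; beyond the scatter) from compound 1 to compound 2 and a 1.3-fold higher number (0.12 log units; within the scatter) from compound 3 to compound 4, 3.7-fold (0.56 log units) apart, beyond the scatter of two such steps. This shows that, among these four compounds, the size of the step is not the same on both cores, but two pairs do not show which feature of the cores goes with the gap, or how the change would read on any further core.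

The compounds shown leave open how a group other than chloro or bromo, such as an amine or a carboxylic acid, would read at the same place on the aromatic ring. They also leave open which of the places where the core of compound 1 and the core of compound 3 differ goes with the gap between the two steps.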